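The source may report more compounds than this note shows. Statements on the series, on what has been measured and on what is new or still open speak of the compounds shown alone.

Measured compounds: compound 1 `CC(C)n1nc(-c2ccon2)c2c(N)ncnc21` gives 7920 nM; compound 3 `Cn1nc(-c2cc(C3CC3)on2)c2c(N)ncnc21` gives 3510 nM; compound 2 `CC(C)n1nc(/C=N/O)c2c(N)ncnc21` is reported only as a limit, > 10000 nM.

In an assay on TT cells for inhibition of proto-oncogene tyrosine-protein kinase receptor Ret variant C634W (Homo sapiens), read by MTT assay, with a stated time of 10 days (on this read-out lower numbers stand for stronger inhibition of growth and higher numbers for weaker inhibition of growth), compound 1 stands highest of the two numbers shown, with compound 3 a lower number. Compound 2 sits at the limit of this assay the limit of > 10000 nM in this assay, at which 1 of the 3 values shown sits, and so carries no number. Compound 4 `CC(C)c1cc(-c2nn(C(C)C)c3ncnc(N)c23)no1` differs from compound 1 by isopropyl in place of hydrogen on an aromatic carbon, on an aromatic carbon of a five-membered aromatic ring with 1 nitrogen and 1 oxygen. Within the data shown here, the only measured step from compound 1, an at least 1.2-fold higher number from compound 1 to compound 2 (0.10 log units; that floor lies within the scatter), exchanges the whole ring and bears little on adding isopropyl; no measured pair isolates this change. Compound 4 is expected to give about 4000 nM, between 1500 nM and 10000 nM. This estimate corresponds to a 2.0-fold lower number from compound 1 to compound 4 (0.30 log units; within the scatter).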

Compound 4, concentration for 50% growth inhibition: 5130 nM
Estimate against measurement, compound 4: 1.3-fold (0.11 log units) below, and the stated range covers the measured number.
By their numbers in this assay, from the lowest: compounds 3, 4 and 1 (each within the scatter of the next, the first and the last beyond it). At a limit, above all of these: compound 2.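

Among these compounds, compound 4 is the first measured case that keeps the five-membered ring of compound 1 and alters only the aromatic carbon next to the ring oxygen. In this assay, isopropyl in place of hydrogen there gives a 1.5-fold lower number from compound 1 to compound 4 (0.19 log units; within the scatter), so the two compounds cannot be told apart and this carbon carries isopropyl without a step beyond the scatter. Nothing shown here offers a reason for this result.

From the compounds shown here alone, whether an amine or a carboxylic acid on this carbon would separate from hydrogen and isopropyl stays open.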